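The compounds below may be only part of what the source reports. "The series", "measured", "known", "first", "only" and "open" are said of these compounds alone.

- compound 1 `Cc1cccc(F)c1-c1nc(CN2CCC(C(=O)NCCCN3C[C@H](C)C[C@H](C)C3)CC2)c(C)o1`: > 72 ug/mL (a limit of the assay, not a number)
- compound 2 `Cc1cccc(C)c1-c1nc(CN2CCC(C(=O)NCCCN3C[C@H](C)C[C@H](C)C3)CC2)c(C)o1`: 55.9 ug/mL

For the measured compounds named here, in a physicochemical assay for solubility, in phosphate buffer, measured as kinetic solubility, at pH 7.4 (a lower number here means a less soluble compound, a higher number a more soluble compound), compound 2 gives 55.9 ug/mL, the only true number so far. Compound 1 provides only a limit. Compound 3 `COc1ccc(-c2nc(CN3CCC(C(=O)NCCCN4C[C@H](C)C[C@H](C)C4)CC3)c(C)o2)cc1OC` brings the change (3,4-dimethoxyphenyl in place of 2,6-dimethylphenyl on an aromatic carbon). Going by the values given here, the one measured step that bears on it is an at least 1.2-fold lower number from compound 1 to compound 2 (0.10 log units; that floor lies within the scatter), a methyl in place of fluoro on an aromatic carbon. It is a much smaller swap and gives little guidance, so no shift beyond the scatter is expected in this assay. The expected step is a 1.1-fold higher number from compound 2 to compound 3 (0.03 log units; within the scatter). For compound 3 the estimated value is 60 ug/mL, with an expected range of 30 ug/mL to 85 ug/mL.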

Compound 3, solubility: > 76 ug/mL
Compound 3: no number, only a limit (the forecaster's own chance of this, stated with the estimate: 30%); middle value at least 1.2-fold (0.10 log units) away from the limit.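

In this assay compound 3 gives only a limit of the assay, > 76 ug/mL. From the compounds shown here alone, putting 3,4-dimethoxyphenyl in place of 2,6-dimethylphenyl gives an at least 1.3-fold higher number from compound 2 to compound 3 (0.13 log units; that floor lies within the scatter), so this position carries a much larger change of aryl group with no fall in the number, though the true size of the step is unknown. The step between the two limit compounds cannot be read.

Going by these compounds, how far compound 3 lies past its limit remains open. Also open, on these data alone, is how an amine or a carboxylic acid on this phenyl ring would read in this assay.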